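The source may report more compounds than this note shows. Statements on the series, on what has been measured and on what is new or still open speak of the compounds shown alone.

Compound 3 `O=C(C1CCC1)N1N=CCC1c1ccccc1` gives 0.583 h in an ADME assay on microsomes (Rattus norvegicus) for metabolic stability; a higher number here means that the compound lasts longer, a lower number that the compound disappears faster. Among the compounds with values here, of the two numbers measured so far this is the higher one: compound 1 `CC(C)(C)C(=O)N1CCSC1c1ccccc1` gives 0.0533 h in this assay, a gap well beyond the scatter. Compound 2 `O=C(C1CCOCC1)N1N=CCC1c1ccccc1` reaches only a limit of the assay, > 1.5 h in this assay. Compound 4 `CC(C)(CO)C(=O)N1N=CCC1c1ccccc1` has not yet been measured. It differs from compound 3 in one place: 1-(hydroxymethyl)-1-methylethyl in place of cyclobutyl on a carbonyl carbon. Within the data shown here, one measured step bears on this change: an at least 2.5-fold lower number from compound 2 to compound 3 (0.41 log units; beyond the scatter). Read the other way, replacing cyclobutyl with oxan-4-yl on the carbonyl carbon went with a longer half-life in this assay. Compound 4 likewise gives up the cyclobutyl on the carbonyl carbon, so a rise beyond the scatter is expected, estimated at a 2.1-fold higher number from compound 3 to compound 4 (0.31 log units; beyond the scatter). The estimate for compound 4 in this assay is 1.2 h, with a likely range from 0.5 h to 3 h. Since one of the three values already sits at the limit of > 1.5 h in this assay, at which 1 of the 3 values shown sits, the assay may report only a limit for compound 4 as well.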

Compound 4, half-life: 0.917 h
Beside the measured number, compound 4's estimate is 1.3-fold (0.12 log units) above it; low and high end bracket the measured number.
By their numbers in this assay, from the lowest: compound 1; then compounds 3 and 4 (each within the scatter of the next). At a limit, above all of these: compound 2.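

In this assay, 1-(hydroxymethyl)-1-methylethyl in place of cyclobutyl on the carbonyl carbon gives a 1.6-fold higher number from compound 3 to compound 4 (0.20 log units; within the scatter), so this change cannot be told apart from no change at all. Where the earlier step showed that swapping one ring for another on this carbonyl carbon can shift the half-life, this step shows that a group with no ring and a hydrogen-bond donor leaves it within the scatter of the cyclobutyl compound. The comparison with the oxan-4-yl group gives an at least 1.6-fold lower number from compound 2 to compound 4 (0.21 log units; that floor lies within the scatter), and the true gap stays unknown, because the value of compound 2 is a limit and not a number: the limit of > 1.5 h in this assay, at which 1 of the 4 values shown sits.

Going by these compounds, whether the hydroxyl itself matters remains open, and a methyl ether in its place would test that on the same core. On these data alone, how an amine or a carboxylic acid at this place would fare in this assay also remains open.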